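The source may hold more compounds than are shown below. What is called first, only, known or untested is meant among the compounds shown, and "the series" means these compounds.

Measured in a functional assay on MDA-MB-231 cells (Homo sapiens) for antiproliferative activity, read by MTT assay, with a stated time of 72 h; on this read-out lower numbers stand for stronger inhibition and higher numbers for weaker inhibition:
- compound 1 `CC1=CC[C@H]2[C@@H]1CC=C(C)[C@@H](CC[C@H]1[C@]3(C)CC[C@H](O)C(C)(C)O[C@H]3CC[C@@]1(C)O)C2(C)C`: > 50000 nM, a limit of the assay
- compound 2 `CC(=O)O[C@H]1CC[C@]2(C)[C@H](CC[C@@](C)(O)[C@H]2CC[C@@H]2C(C)=CC[C@H]3[C@H](CC[C@]3(C)O)C2(C)C)OC1(C)C`: 38000 nM
- compound 3 `CC1=CC[C@H]2[C@H](CC[C@]2(C)O)C(C)(C)[C@@H]1CC[C@H]1[C@]2(C)CC[C@H](OC(=O)c3ccc(Cl)cc3)C(C)(C)O[C@H]2CC[C@@]1(C)O`: 10300 nM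

Compound 1 stands at the limit of > 50000 nM in this assay, at which 1 of the 3 values shown sits, so it has a limit and not a number. Compound 4 `CC1=CC[C@H]2[C@@H]1CC=C(C)[C@@H](CC[C@H]1[C@]3(C)CC[C@H](OC(=O)c4ccc(Cl)cc4)C(C)(C)O[C@H]3CC[C@@]1(C)O)C2(C)C` is compound 1 with a single change: (4-chlorophenyl)carbonyl in place of hydrogen on an oxygen on a saturated carbon. In words, (4-chlorophenyl)carbonyl takes the place of hydrogen on an oxygen on a saturated carbon, turning hydroxy into ((4-chlorophenyl)carbonyl)oxy.

For the measured compounds named here, no measured pair makes exactly this change. The closest evidence is a 3.7-fold lower number from compound 2 to compound 3 (0.57 log units; beyond the scatter), where 4-chlorophenyl replaces methyl on a carbonyl carbon. That step is modest but beyond the scatter, and the core shared by compound 2 and compound 3 is not quite the core of compound 1. Compound 3 already carries the entering group and gives 10300 nM in this assay, so a similar number looks reasonable, with wide uncertainty. A step to a lower number is therefore expected: an at least 3.8-fold lower number from compound 1 to compound 4 (0.58 log units; beyond the scatter). For compound 4 the estimated value is 13000 nM, with an expected range from 5000 nM to 35000 nM.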

Compound 4, half-maximal inhibitory concentration: 12700 nM
For compound 4 the middle estimate is 1.0-fold (0.01 log units) above the measured one; the range from low to high includes it.
By their numbers in this assay, from the lowest: compounds 3 and 4 (each within the scatter of the next); then compound 2. At a limit, above all of these: compound 1.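

In this assay, the change from hydroxy to ((4-chlorophenyl)carbonyl)oxy gives an at least 3.9-fold lower number from compound 1 to compound 4 (0.59 log units; beyond the scatter). For the compounds shown here, the earlier pair pointed the same way, but on a related core, so this is the first direct sign that the change lowers the number on the core of compound 1 as well. The true size of this step stays unknown because only one end of it is a number: the limit of > 50000 nM in this assay, at which 1 of the 4 values shown sits.

The compounds shown leave open whether the 4-chlorophenyl matters in itself or whether any larger group on this carbonyl would do the same, as a longer chain or a group carrying an amine might. They also leave open whether a carboxylic acid or another halogen on the aromatic ring would move compound 4 further from its 12700 nM.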